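Swapping 4-nitrophenyl for 3-fluorophenyl

A few compounds are considered here, and "the series" means these few. Any claim that something is new, unique, unknown or untested is made for them only; others in the source may bear on it.

In a functional assay on MCF7 cells (Homo sapiens) for antiproliferative activity, read by MTT assay, with a stated time of 72 h (a lower number here means a stronger inhibitor, a higher number a weaker inhibitor), compound 3 (`COc1cc(-n2cnc3ccc(-c4ccc([N+](=O)[O-])cc4)cc32)cc(OC)c1OC`) gives 740 nM as the lowest number shown, and compound 2 (`COc1cc(-n2cnc3ccc(-c4cc(F)ccc4F)cc32)cc(OC)c1OC`) gives 6420 nM as a clearly higher one. Compound 1 (`COc1cc(-n2cnc3ccc(-c4ccccc4Cl)cc32)cc(OC)c1OC`) returns only a limit of the assay, > 10000 nM and no exact number. Compound 4 (`COc1cc(-n2cnc3ccc(-c4cccc(F)c4)cc32)cc(OC)c1OC`) carries 3-fluorophenyl in place of 4-nitrophenyl on an aromatic carbon. Two measured steps that arrive at the 4-nitrophenyl group bear on this change, one large and one modest: an at least 13-fold lower number from compound 1 to compound 3 (1.13 log units; beyond the scatter) and an 8.7-fold lower number from compound 2 to compound 3 (0.94 log units; beyond the scatter) are both beyond the scatter. Reading those steps backwards, a modest rise in the number is expected for compound 4 in this assay and thus a weaker inhibitor. The expected change is a 6.1-fold higher number from compound 3 to compound 4 (0.78 log units; beyond the scatter) in size. Compound 4 is estimated at 4500 nM within an expected range of 1500 nM to 13000 nM here.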

Compound 4, half-maximal inhibitory concentration: 2350 nM
The estimate for compound 4 lay 1.9-fold (0.28 log units) above the measured number; measured number inside the range.
By their numbers in this assay, from the lowest: compound 3; then compound 4; then compound 2. At a limit, above all of these: compound 1.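

The 4-nitrophenyl group keeps its lead, with a 3.2-fold higher number from compound 3 to compound 4 (0.50 log units; beyond the scatter), but this position tolerates a ring without a nitro group better than compound 2 suggested. Hydrogen in place of one fluoro lowers the number, with a 2.7-fold lower number from compound 2 to compound 4 (0.44 log units; beyond the scatter), so a second fluoro brings no gain in this pair. Compound 1 gives only a limit, so an at least 4.2-fold lower number from compound 1 to compound 4 (0.62 log units; beyond the scatter) is a floor and not an exact size: the limit of > 10000 nM in this assay, at which 1 of the 4 values shown sits.

Still open, going by these compounds, is whether the nitro group itself or its place on the ring drives the low number of compound 3. An amine or a carboxylic acid at that place would help separate the two.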